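The compounds below may be only part of what the source reports. "The series", "measured", "known", "first", "only" and "open" are said of these compounds alone.

Compound 3 `COc1cc(-c2nc(C(c3ccc(F)cc3)c3ccc(F)cc3)sc2CC(=O)O)ccn1` gives 380 nM in an in vitro functional assay on HEK285-7 cells for antagonist activity at prostaglandin D2 receptor 2 (Homo sapiens), read by BRET and beta-arrestin recruitment (a higher number here means a weaker inhibitor, a lower number a stronger inhibitor), and its number sits among those of its two companions: compound 1 `O=C(O)Cc1sc(C(c2ccc(F)cc2)c2ccc(F)cc2)nc1-c1ccccc1` gives 240 nM and compound 2 `N#Cc1cc(-c2nc(C(c3ccc(F)cc3)c3ccc(F)cc3)sc2CC(=O)O)ccc1F` gives 520 nM, with a 1.6-fold higher number from compound 1 to compound 3 (0.20 log units; within the scatter) and a 1.4-fold lower number from compound 2 to compound 3 (0.14 log units; within the scatter). Compound 4 `O=C(O)Cc1sc(C(c2ccc(F)cc2)c2ccc(F)cc2)nc1-c1ccnc(N2CCC2)c1` differs from compound 3 in one place: azetidin-1-yl in place of methoxy on an aromatic carbon. Within the data shown here, no measured step touches this part of the ring. Among the measured compounds shown here, the nearest comparison, from compound 1 to compound 3, exchanges the whole ring and still stays within the scatter, while a 2.2-fold higher number from compound 1 to compound 2 (0.34 log units; beyond the scatter) is the only step here that reaches beyond it. Compound 4 is therefore expected to show a 1.1-fold higher number from compound 3 to compound 4 (0.02 log units; within the scatter), meaning no shift beyond the scatter. The estimate for compound 4 is 400 nM, with a range from 150 nM to 1000 nM.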

Compound 4, half-maximal inhibitory concentration: > 100000 nM
Compound 4: a limit, no number; the forecaster's own chance of this, stated with the estimate: 3%; at least 250-fold (2.39 log units) between middle value and limit.
By their numbers in this assay, from the lowest: compounds 1, 3 and 2 (each within the scatter of the next, the first and the last beyond it). At a limit, above all of these: compound 4.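

In this assay compound 4 stands at a limit of the assay, not at a number: the limit of > 100000 nM in this assay, at which 1 of the 4 values shown sits. Among these compounds, exchanging the whole ring had given only small steps among the earlier compounds, yet replacing methoxy with azetidin-1-yl on the carbon next to the ring nitrogen gives an at least 260-fold higher number from compound 3 to compound 4 (2.42 log units; beyond the scatter), so this one position tolerates far less change than those steps suggested. The other two comparisons are also large: an at least 190-fold higher number from compound 2 to compound 4 (2.28 log units; beyond the scatter) and an at least 410-fold higher number from compound 1 to compound 4 (2.61 log units; beyond the scatter). Still open, as far as these compounds go, is whether the four-membered ring itself matters, or whether any nitrogen attached at this carbon has the same result. A primary amine, dimethylamino or pyrrolidin-1-yl group there would help separate these possibilities.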